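The compounds below may be only part of what the source reports. "The series", "measured", "known", "first", "only" and "open" are said of these compounds alone.

The shared core is that of compound 1 `O=C(/C=C/c1ccccc1)c1ccc[nH]1`. In a functional assay on PC-3 cells (Homo sapiens) for inhibition, read by MTT assay, with a stated time of 48 h (on this read-out higher numbers stand for weaker inhibition and lower numbers for stronger inhibition), compound 1 gives > 100000 nM, which is a limit of the assay and not a number (the limit of > 100000 nM in this assay, at which 1 of the 3 values shown sits). Compound 2 `O=C(/C=C/c1ccc([N+](=O)[O-])cc1)c1ccc[nH]1` gives 13000 nM in this assay, and compound 3 `O=C(/C=C/c1cccc([N+](=O)[O-])c1)c1ccc[nH]1` gives 23000 nM. Among the two numbers shown, compound 2 stands lowest, with compound 3 nearest at a gap that lies within the scatter. The two steps that carry a number both start from compound 1: there is an at least 7.6-fold lower number from compound 1 to compound 2 (0.88 log units; beyond the scatter) and, for the other position, an at least 4.3-fold lower number from compound 1 to compound 3 (0.63 log units; beyond the scatter).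

Compound 4 `O=C(/C=C/c1ccc(Cl)cc1)c1ccc[nH]1` has not been measured in this assay. It differs from compound 2 by chloro in place of nitro on an aromatic carbon. Going by the values given here, no measured step exchanges nitro for another group; both measured steps show nitro entering in place of hydrogen, and the compound without nitro sits at the limit. Those steps therefore bear on the present change only at one remove. On that basis the expected step is a 3.1-fold higher number from compound 2 to compound 4 (0.49 log units; beyond the scatter), a modest rise in the number. For compound 4 the estimate in this assay is 40000 nM, with a range from 12000 nM to 130000 nM.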

Compound 4, half-maximal inhibitory concentration: 18000 nM
Beside the measured number, compound 4's estimate is 2.2-fold (0.35 log units) above it; the measured number falls inside the stated range.
By their numbers in this assay, from the lowest: compounds 2, 4 and 3 (each within the scatter of the next). At a limit, above all of these: compound 1.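

At the aromatic carbon para to a group of 9 heavy atoms, the exchange of nitro for chloro gives a 1.4-fold higher number from compound 2 to compound 4 (0.14 log units; within the scatter) in this assay, so compound 2 and compound 4 cannot be told apart on this read-out. The earlier compounds showed only nitro entering the shared core, whereas this result shows that a single chloro also moves the number clear of the limit, with an at least 5.5-fold lower number from compound 1 to compound 4 (0.74 log units; beyond the scatter); at this position, the requirement is therefore not specific to nitro among the two groups shown. That step gives a bound and not an exact size, as compound 1 stands at a limit of the assay and not at a number: the limit of > 100000 nM in this assay, at which 1 of the 4 values shown sits.

The compounds shown leave open whether the same tolerance extends to groups of other kinds at this position, such as an amine, a carboxylic acid or a methoxy group, and whether a group larger than nitro would still fit this pattern. They also leave open whether chloro would match nitro at the position that carries nitro in compound 3, and what the unsubstituted compound's true number is.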